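Cytotoxicity notes on the step to compound 3

This account rests on a few compounds, and the source may have more. Where it says the series, first, only, none or still open, it means among the compounds named here.

Measured in a functional assay on Huh-5-2 cells (Homo sapiens), read by MTT assay; on this read-out lower numbers stand for higher toxicity in this test and higher numbers for lower toxicity in this test:
- compound 1 `O=C(O)c1ccc(-c2ccc(Cl)cc2COc2ccc(-c3nc4cc(C(=O)O)ccc4n3C3CCCCC3)cc2)cc1`: > 50000 nM (a limit, not a number)
- compound 2 `CN(C)c1ccc(-c2ccc(Cl)cc2)c(COc2ccc(-c3nc4cc(C(=O)O)ccc4n3C3CCCCC3)cc2)c1`: 30000 nM

Going by the values given here, compound 2 at 30000 nM holds the only actual number so far. Compound 3 `O=C(O)c1ccc2c(c1)nc(-c1ccc(OCc3cc(C(=O)NCc4ccccc4)ccc3-c3ccc(Cl)cc3)cc1)n2C1CCCCC1` has benzylcarbamoyl in place of dimethylamino on an aromatic carbon. Among the compounds with values here, no measured step covers this change. In this assay no step beyond the scatter is expected, with compound 2 at 30000 nM as the sole anchor. The estimated no change at the digits printed from compound 2 to compound 3 (within the scatter) is expected to stay within the usual scatter. For compound 3 the estimated value is 30000 nM with an expected range of 13000 nM to 60000 nM on this read-out.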

Compound 3, half-maximal cytotoxic concentration: 22000 nM
Estimate against measurement, compound 3: 1.4-fold (0.13 log units) above; low and high end bracket the measured number.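

In this assay, benzylcarbamoyl in place of dimethylamino on this aromatic carbon, para to a 4-chlorophenyl group, gives a 1.4-fold lower number from compound 2 to compound 3 (0.13 log units; within the scatter). Going by these compounds alone, this is the first step that can be read between two actual numbers. It shows that this position carries the larger group, with its six-membered aromatic ring and hydrogen-bond donor, without a shift beyond the scatter.

Going by these compounds, how a primary amine or a longer alkyl chain would read at this position stays open. Compound 1 gives only a limit, not a number: the limit of > 50000 nM in this assay, at which 1 of the 3 values shown sits.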